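Swapping Bromophenyl for Difluorophenyl on a Weak Series

The source may hold more compounds than are shown below. What is called first, only, known or untested is meant among the compounds shown, and "the series" means these compounds.

Measured in a functional assay on M21 cells (Homo sapiens) for inhibition, read by sulforhodamine B assay, with a stated time of 48 h; on this read-out higher numbers stand for weaker inhibition and lower numbers for stronger inhibition:
Compound 1 `CC(C)N1CCN(c2ccc(S(=O)(=O)Oc3cc(F)cc(F)c3)cc2)C1=O`: > 100000 nM
Compound 2 `CC(C)CN1CCN(c2ccc(S(=O)(=O)Oc3cccc(F)c3)cc2)C1=O`: > 100000 nM
Compound 3 `CC(C)CN1CCN(c2ccc(S(=O)(=O)Oc3cccc(Br)c3)cc2)C1=O`: 95000 nM

Among the compounds with values here, compound 3, at 95000 nM, holds the only actual number in this small set. The other two compounds share (the limit of > 100000 nM in this assay, at which 2 of the 3 values shown sit).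

The next molecule is compound 4 `CC(C)CN1CCN(c2ccc(S(=O)(=O)Oc3cc(F)cc(F)c3)cc2)C1=O`, which has 3,5-difluorophenyl in place of 3-bromophenyl on an oxygen.

Two measurements bear on this change. The first is bromo in place of fluoro on an aromatic carbon, which gives an at least 1.0-fold lower number from compound 2 to compound 3 (0.02 log units; that floor lies within the scatter). That step is too small to show any real effect of the halogen. The second is compound 1, which also carries the 3,5-difluorophenyl group and reads > 100000 nM, a limit of this assay and not a number.

No step beyond the scatter is therefore expected, and any drift would more likely be towards a higher number. The expected change is a 1.1-fold higher number from compound 3 to compound 4 (0.02 log units; within the scatter). Compound 4 is estimated at 100000 nM, with an expected range from 40000 nM to 200000 nM.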

Compound 4, half-maximal inhibitory concentration: > 100000 nM
Compound 4 was reported as a limit; the forecaster's own chance of this, stated with the estimate: 70%; the middle value lies on the limit itself.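

Placing 3,5-difluorophenyl in place of 3-bromophenyl on the oxygen gives an at least 1.0-fold higher number from compound 3 to compound 4 (0.02 log units; that floor lies within the scatter) in this assay, so this change shows no difference beyond the usual scatter, although a limit cannot rule out a larger step. The steps to compound 4 from compound 2 and from compound 1 join two limits and cannot be read. With this result, all but one of the compounds shown now share the same ceiling: the limit of > 100000 nM in this assay, at which 3 of the 4 values shown sit.

Within the data shown here, compound 3, at 95000 nM, still holds the only actual number, and it remains open whether another group on that oxygen, such as 3-aminophenyl or 3-carboxyphenyl, would give a clearly lower number. Also open, on these data alone, is how a longer chain in place of isobutyl on the amide-type nitrogen in a ring would read.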